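From compound 2 to compound 3: a 3,5-dichlorophenyl swap

The source may report more compounds than this note shows. Statements on the series, on what has been measured and on what is new or still open speak of the compounds shown alone.

Compound 1 (`O=C(Nc1ccc(Nc2ncnc3c2OCCN3)cc1)Nc1ccc(C(F)(F)F)cc1`) gives 10000 nM in a functional assay on BaF3 cells (Mus musculus) for inhibition, read by MTT assay, with a stated time of 3 days; on this read-out higher numbers stand for weaker inhibition of growth and lower numbers for stronger inhibition of growth.

Compound 2 (`Cc1cc(C)cc(NC(=O)Nc2ccc(Nc3ncnc4c3OCCN4)cc2)c1`) gives > 10000 nM in this assay, and this is a limit of the assay and not a number.

Compound 3 (`O=C(Nc1ccc(Nc2ncnc3c2OCCN3)cc1)Nc1cc(Cl)cc(Cl)c1`) has 3,5-dichlorophenyl in place of 3,5-dimethylphenyl on an amide-type nitrogen, with the carbonyl carbon as its other neighbour: 3,5-dichlorophenyl in place of 3,5-dimethylphenyl on an amide-type nitrogen.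

Going by the values given here, only one measured step bears on this change: a number no lower from compound 1 to compound 2 (the limit leaves the size open). It concerns the same place in the series, and its size cannot be read. The limit behind it is the limit of > 10000 nM in this assay, at which 1 of the 2 values shown sits.

Neither measured compound shows strong inhibition of growth, so the expectation rests on compound 1 at 10000 nM. At most a small move toward stronger inhibition is expected in this assay, and a further reading at the limit is about as likely.

The expected size is an at least 1.2-fold lower number from compound 2 to compound 3 (0.09 log units; that floor lies within the scatter).

For compound 3 the estimated value is 8000 nM, with an expected range of 3000 nM to 20000 nM.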

Compound 3, concentration for 50% growth inhibition: 10000 nM
Compound 3: middle estimate off by 1.3-fold (0.10 log units), on the low side; the range from low to high includes it.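

In this assay, exchanging the 4-(trifluoromethyl)phenyl group for 3,5-dichlorophenyl gives no change at the digits printed from compound 1 to compound 3 (within the scatter), so these two groups cannot be told apart here. This position previously held one number and one limit; it now holds two numbers, and neither shows strong inhibition of growth. Exchanging the 3,5-dimethylphenyl group for 3,5-dichlorophenyl gives a number no higher from compound 2 to compound 3 (the limit leaves the size open). Compound 2 remains at a limit of the assay, > 10000 nM, so its steps to the other two compounds cannot be read: the limit of > 10000 nM in this assay, at which 1 of the 3 values shown sits.

Still open, on these data alone, is whether any group on this amide-type nitrogen can move the number beyond the scatter, or whether the shared core stays weak in this assay whichever group sits there. A phenyl ring carrying a carboxylic acid or an aminomethyl group, or a longer alkyl chain in place of the ring, would probe this position with groups unlike the three substituted phenyl rings shown.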